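A few compounds are considered here, and "the series" means these few. Any claim that something is new, unique, unknown or untested is made for them only; others in the source may bear on it.

Measured compounds:
Compound 1 `Cc1ccc2ccccc2c1-c1cccc(COc2ccc3c(c2)OCC3CC(=O)O)c1` gives 41 nM in an assay on CHO cells for displacement of a labelled ligand from Free fatty acid receptor 1 (Homo sapiens), read by scintillation counting, with a stated time of 90 min, in the presence of a further agent that is not named here; on this read-out higher numbers stand for weaker inhibition and lower numbers for stronger inhibition.
Compound 2 `O=C(O)CC1COc2cc(OCc3cccc(-c4csc5ccccc45)c3)ccc21` gives 290 nM in this assay.

Compound 2 stands at the higher of the two numbers in this assay; the nearer, compound 1, sits below it by a gap beyond the scatter. Compound 3 `O=C(O)CC1COc2cc(OCc3cccc(-c4ccc5sccc5c4)c3)ccc21` follows from compound 2 by a rearrangement: 1-benzothiophen-5-yl in place of 1-benzothiophen-3-yl on an aromatic carbon. For the measured compounds named here, no measured pair shows a step of this kind, so the size of the step in this assay is uncertain; a change not beyond the scatter, in either direction, is expected. Compound 3 is therefore estimated at 250 nM, within 80 nM to 800 nM, a step of a 1.2-fold lower number from compound 2 to compound 3 (0.06 log units; within the scatter) expected.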

Compound 3, inhibition constant: 570 nM
The estimate for compound 3 lay 2.3-fold (0.36 log units) below the measured number, and the stated range covers the measured number.
By their numbers in this assay, from the lowest: compound 1; then compounds 2 and 3 (each within the scatter of the next).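

Replacing 1-benzothiophen-3-yl with 1-benzothiophen-5-yl on this aromatic carbon, meta to a large group, gives a 2.0-fold higher number from compound 2 to compound 3 (0.29 log units; within the scatter) in this assay. For the compounds shown here, this is the first measured step at this position, and it shows that these two attachments of the same bicyclic group are not told apart in this assay. No available evidence bears on the reason for this result.

On these data alone, it remains open whether an amine or a methoxy group on the 1-benzothiophen-5-yl ring would keep the number within the scatter of compound 3.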